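The source may hold more compounds than are shown below. What is called first, only, known or untested is meant among the compounds shown, and "the series" means these compounds.

Measured compounds:
compound 1, `COc1cc(CCc2ccccn2)cc(OC)c1O`: 660 nM
compound 2, `COc1cc(CCc2ccc(Cl)cc2)cc(OC)c1O`: > 25000 nM
compound 3, `COc1cc(CCc2ccccc2Cl)cc(OC)c1O`: 24500 nM

All three share the same core and were tested in a functional assay on MKN-45 cells (Homo sapiens) for antiproliferative activity, read by MTT assay, with a stated time of 72 h; on this read-out lower numbers stand for stronger inhibition and higher numbers for weaker inhibition. Of the two numbers obtained, compound 1 has the lowest; its nearest neighbour, compound 3, sits well beyond the usual scatter, so compound 1 is clearly the stronger of the two. For compound 2 the assay returned only a limit, > 25000 nM, not a number. Both compounds with a chlorine on the ring are thus weak, while the pyridine of compound 1 stands out.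

The next compound, compound 4, `COc1cc(CCc2ccncc2)cc(OC)c1O`, is built from the same atoms as compound 1: pyridin-4-yl in place of pyridin-2-yl on a saturated chain carbon, two bonds along the chain from an aromatic carbon. Among the measured compounds shown here, no measured pair in this set shows what moving the ring nitrogen does, so the expectation rests on compound 1 alone. The step from compound 1 to compound 4 is expected to be a 2.3-fold higher number from compound 1 to compound 4 (0.36 log units; beyond the scatter) in this assay, a mild weakening, though it could also stay within the scatter. Compound 4 is estimated at 1500 nM, with a range from 300 nM to 8000 nM.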

Compound 4, half-maximal inhibitory concentration: 3810 nM
Compound 4: middle estimate off by 2.5-fold (0.40 log units), on the low side, within the range that was stated.
By their numbers in this assay, from the lowest: compound 1; then compound 4; then compound 3. At a limit, above all of these: compound 2.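

Moving the ring nitrogen, with no atom added or lost, is enough to change the result in this assay: pyridin-4-yl in place of pyridin-2-yl on a saturated chain carbon gives a 5.8-fold higher number from compound 1 to compound 4 (0.76 log units; beyond the scatter). Among the compounds shown here, this position therefore responds not only to which kind of ring is attached, but also to where the nitrogen sits within that ring, something the earlier compounds could not show because no two of them formed such a pair. Nothing measured here explains why the place of the nitrogen matters so much.

From the compounds shown here alone, it remains open whether pyridin-3-yl would give a number closer to that of compound 1 or of compound 4, and what an unsubstituted phenyl ring would do at this position. A longer chain carrying pyridin-2-yl is also untested among the compounds shown, so the effect of chain length on this result is unknown.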